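This account rests on a few compounds, and the source may have more. Where it says the series, first, only, none or still open, it means among the compounds named here.

Compound 1, `COc1ccc(F)cc1N1C(=O)CSC1c1cccc(C(=O)NCCCCc2ccccc2)c1`, in a functional assay on HOS-TE85 cells (Homo sapiens) for inhibition, read by CCK-8 assay, with a stated time of 72 h; a lower number here means a stronger inhibitor, a higher number a weaker inhibitor: 8.8 nM
Compound 2, `O=C(NCCCCc1ccccc1)c1cccc(C2SCC(=O)N2c2ccccc2)c1`, in this assay: 15.9 nM

For the measured compounds named here, of the two numbers measured so far, compound 2 has the higher one, and its nearest neighbour is compound 1; the step between them, a 1.8-fold higher number from compound 1 to compound 2 (0.26 log units; within the scatter), came with phenyl in place of 5-fluoro-2-methoxyphenyl on an amide-type nitrogen in a ring. Compound 3, `CC(F)(F)c1cccc(N2C(=O)CSC2c2cccc(C(=O)NCCCCc3ccccc3)c2)c1`, is compound 2 with one change: 1,1-difluoroethyl in place of hydrogen on an aromatic carbon, on a six-membered aromatic ring of carbon only. Going by the values given here, the only step measured, a 1.8-fold higher number from compound 1 to compound 2 (0.26 log units; within the scatter), concerns the same ring but replaces it entirely, so it bears on the new change only loosely; what it does show is that altering that ring moved the number little. The expected step for compound 3 is therefore a 1.1-fold lower number from compound 2 to compound 3 (0.03 log units; within the scatter), with no direction claimed. Compound 3 is estimated at 15 nM, in the range 6 nM to 40 nM.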

Compound 3, half-maximal inhibitory concentration: 29.1 nM
For compound 3 the middle estimate is 1.9-fold (0.29 log units) below the measured one, and the stated range covers the measured number.
By their numbers in this assay, from the lowest: compounds 1, 2 and 3 (each within the scatter of the next, the first and the last beyond it).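

Adding 1,1-difluoroethyl on an aromatic carbon of the ring of compound 2, meta to a large group, leaves the result in this assay within the scatter, with a 1.8-fold higher number from compound 2 to compound 3 (0.26 log units; within the scatter), so this position accepts a group of this size without a clear loss. For the compounds shown here, the same compound stands further from compound 1, with a 3.3-fold higher number from compound 1 to compound 3 (0.52 log units; beyond the scatter), the only step here beyond the scatter, though it is modest and involves exchanging the whole group on the ring nitrogen. Nothing available offers an explanation for either step.

The compounds shown leave open whether methyl, trifluoromethyl, an amine or a carboxylic acid on the same aromatic carbon would stay in this range. They also leave open how 1,1-difluoroethyl would fare on another carbon of that ring.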